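A few compounds are considered here, and "the series" means these few. Any claim that something is new, unique, unknown or untested is made for them only; others in the source may bear on it.

In a functional assay on HepG2 cells (Homo sapiens) for cytotoxicity, read by MTT assay, with a stated time of 72 h (on this read-out higher numbers stand for weaker inhibition and lower numbers for stronger inhibition), compound 1 `COc1cc2ncnc(Nc3ccc(F)c(Cl)c3)c2cc1NC(=O)N/N=C/c1cc(OC)c(OC)c(OC)c1` gives 30100 nM. Compound 2 `COc1cc2ncnc(Nc3ccc(F)c(Cl)c3)c2cc1NC(=O)N/N=C/c1ccc(O)c(Br)c1` gives 23800 nM, which places it level with compound 1 within the scatter. The next compound, compound 3 `COc1cc2ncnc(Nc3ccc(F)c(Cl)c3)c2cc1NC(=O)N/N=C/c1ccc(O)cc1O`, differs from compound 2 as follows: 2,4-dihydroxyphenyl in place of 3-bromo-4-hydroxyphenyl on a carbon with a double bond to nitrogen. In words, this is 2,4-dihydroxyphenyl in place of 3-bromo-4-hydroxyphenyl on a carbon with a double bond to nitrogen. Going by the values given here, only one measured step bears on this change, the exchange at the same place, a 1.3-fold lower number from compound 1 to compound 2 (0.10 log units; within the scatter), and it stays within the scatter. One step is a thin basis, but it gives no reason to expect a step beyond the scatter in this assay, and no direction is favoured. The expected step is a 1.1-fold higher number from compound 2 to compound 3 (0.02 log units; within the scatter). Compound 3 is estimated at 25000 nM, with an expected range of 10000 nM to 60000 nM.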

Compound 3, half-maximal inhibitory concentration: 32100 nM
Compound 3: middle estimate off by 1.3-fold (0.11 log units), on the low side, within the range that was stated.
By their numbers in this assay, from the lowest: compounds 2, 1 and 3 (each within the scatter of the next).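

Working notes: in this assay a third group at this place, on a carbon with a double bond to nitrogen, still gives only a step within the scatter, with a 1.3-fold higher number from compound 2 to compound 3 (0.13 log units; within the scatter) and a 1.1-fold higher number from compound 1 to compound 3 (0.03 log units; within the scatter). Loss of the bromine and the change from 1 hydrogen-bond donor in 3-bromo-4-hydroxyphenyl to 2 in 2,4-dihydroxyphenyl therefore come with no readable difference, and compounds 1, 2 and 3 stand level, with no compound among them going against this. No supporting data are available to account for this flat result.

Going by these compounds, whether an amine, a carboxylic acid or a longer chain at this place would give a step beyond the scatter remains open. Also open, on these data alone, is whether any change to the shared core would do so in this assay.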